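The source may hold more compounds than are shown below. What is called first, only, known or untested is meant among the compounds shown, and "the series" means these compounds.

Working notes on the series: in a functional assay on HeLa cells (Homo sapiens) for cytotoxicity, read by MTT assay, with a stated time of 24 h (a higher number here means a weaker inhibitor, a lower number a stronger inhibitor), compound 1 (`COc1cc(/C=C2\CN(C)C/C(=C\c3ccccc3F)C2=O)cc(OC)c1`) gives 5450 nM as the top of three numbers, though not clear of compound 2 (`COc1cc(/C=C2\CN(C)C/C(=C\c3ccccc3F)C2=O)cc(OC)c1OC`) at 3220 nM but clear of compound 3 (`CN1C/C(=C\c2cccc([N+](=O)[O-])c2)C(=O)/C(=C/c2ccccc2F)C1`) at 2340 nM by more than the scatter. Among the measured compounds shown here, compound 4 (`COc1cc(/C=C2\CN(C)C/C(=C\c3ccc(Cl)cc3)C2=O)cc(OC)c1`) departs from compound 1 through 4-chlorophenyl in place of 2-fluorophenyl on a double-bonded chain carbon bound to a double-bonded ring carbon at a place no measured step has touched. For the measured compounds named here, the one step available, a 1.7-fold lower number from compound 1 to compound 2 (0.23 log units; within the scatter), is methoxy in place of hydrogen on an aromatic carbon, elsewhere on the molecule, so it offers only weak guidance. No step beyond the scatter is therefore expected in this assay and the estimated step is a 1.4-fold lower number from compound 1 to compound 4 (0.13 log units; within the scatter) at most. Compound 4 is expected at 4000 nM within an estimated range of 1500 nM to 10000 nM in this series.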

Compound 4, half-maximal inhibitory concentration: 11200 nM
Compound 4: middle estimate off by 2.8-fold (0.45 log units), on the low side; the measured number lies above the stated range.
By their numbers in this assay, from the lowest: compounds 3, 2 and 1 (each within the scatter of the next, the first and the last beyond it); then compound 4.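

Among the compounds shown here, the first step at this place is a 2.1-fold higher number from compound 1 to compound 4 (0.31 log units; beyond the scatter), with 4-chlorophenyl in place of 2-fluorophenyl on a double-bonded chain carbon bound to a double-bonded ring carbon, so this position responds to the change beyond the scatter in this assay and in the weaker direction. This single pair changes both the halogen and its position on the phenyl ring, and the step cannot be divided between the two. No supporting data offer an explanation for the step.

Open, as far as these compounds go, is whether 2-chlorophenyl or 4-fluorophenyl would separate those two changes. Also open, from the compounds shown here alone, is how an amine or a carboxylic acid on this phenyl ring would read in this assay.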